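Removing the benzyl ester from a leucine-type analogue

The source may hold more compounds than are shown below. What is called first, only, known or untested is meant among the compounds shown, and "the series" means these compounds.

Measured compounds:
Compound 1, `CC[C@H](C)[C@H](NC(=O)CN(c1nc(Cl)nc2[nH]cnc12)C1CC1)C(=O)O`, gives 30.3% in a functional assay on the whole organism (Tail, strain ICR) with Mus musculus as the target, in the tail flick test, with a stated time of 30 min, at a dose of 25 umol/kg by the oral route; on this read-out higher numbers stand for a stronger effect at the one dose given and lower numbers for a weaker effect.
Compound 2, `CC[C@H](C)[C@H](NC(=O)CN(c1nc(Cl)nc2[nH]cnc12)C1CC1)C(=O)OCc1ccccc1`, gives 41.4% in this assay.
Compound 3, `CC(C)C[C@H](NC(=O)CN(c1nc(Cl)nc2[nH]cnc12)C1CC1)C(=O)OCc1ccccc1`, gives 33.9% in this assay.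

All three share one core and differ only at the ester end or at the side chain of the amino acid part. Compound 2 carries a benzyl ester and compound 1 the free acid; that change, (hydrogen in place of benzyl on an oxygen next to a carbonyl group), gave a number 11.1 percentage points lower from compound 2 to compound 1 (beyond the scatter). Compound 3 differs from compound 2 in the side chain, (isobutyl in place of sec-butyl on a saturated chain carbon bound to an amide-type nitrogen and a carbonyl carbon), and the step of a number 7.5 percentage points lower from compound 2 to compound 3 (within the scatter) lies within the usual scatter, so the two cannot be ranked.

Compound 4, `CC(C)C[C@H](NC(=O)CN(c1nc(Cl)nc2[nH]cnc12)C1CC1)C(=O)O`, is not yet measured. It differs from compound 3 by hydrogen in place of benzyl on an oxygen next to a carbonyl group, the same change seen from compound 2 to compound 1, made on the other side chain. If that change carries over, the expected step is a number 10.9 percentage points lower from compound 3 to compound 4 (beyond the scatter), resting on the single earlier step of a number 11.1 percentage points lower from compound 2 to compound 1 (beyond the scatter). Within the data shown here, the estimate for compound 4 is therefore 23%, expected to lie between 10% and 38%, with the width reflecting that only one prior example of this change exists.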

Compound 4, a percentage reported as activity, at one dose (the size of the read-out at that dose, not a potency): 23.4%
Compound 4: middle estimate off by 0.4 percentage points, on the low side; low and high end bracket the measured number.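

In this assay, hydrogen in place of benzyl on an oxygen next to a carbonyl group gave a number 10.5 percentage points lower from compound 3 to compound 4 (beyond the scatter), which matches the step already seen on the sec-butyl side chain: the same change on two cores in this assay, a number 11.1 percentage points lower (beyond the scatter) from compound 2 to compound 1 and a number 10.5 percentage points lower (beyond the scatter) from compound 3 to compound 4, 0.6 percentage points apart, within the scatter of two such steps

Isobutyl in place of sec-butyl, now on the free acids, gave a number 6.9 percentage points lower from compound 1 to compound 4 (within the scatter), and this step also repeats, although neither of its two instances can be told from scatter: the same change on two cores in this assay, a number 7.5 percentage points lower (within the scatter) from compound 2 to compound 3 and a number 6.9 percentage points lower (within the scatter) from compound 1 to compound 4, 0.6 percentage points apart, within the scatter of two such steps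

So the ester change carried over between these two side chains at about the same size, but this rests on only two matched pairs at one dose and one time, and it does not show why the number falls or whether the step would hold on a more different core.

The compounds shown leave open whether another ester, such as a methyl or ethyl ester, or an amide at that end would behave like the benzyl ester. They also leave open how side chains other than isobutyl and sec-butyl, such as a longer chain or one carrying an amine, would respond to the same change.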